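Cyclopropane amides with trimethoxyphenyl: hydroxymethyl for ester

The source may hold more compounds than are shown below. What is called first, only, known or untested is meant among the compounds shown, and "the series" means these compounds.

Compound 1 `COc1cc([C@@H]2C[C@]2(CO)C(=O)NCc2ccc(C)cc2)cc(OC)c1OC`, compound 2 `CCOC(=O)[C@]1(C(=O)NCc2ccc(C)cc2)C[C@H]1c1cc(OC)c(OC)c(OC)c1` and compound 3 `CCOC(=O)[C@@]1(C(=O)Nc2ccccc2Cl)C[C@H]1c1cc(OC)c(OC)c(OC)c1` were tested in a functional assay on K562 cells (Homo sapiens) for cytotoxicity, read by MTT assay, with a stated time of 48 h; on this read-out higher numbers stand for weaker inhibition and lower numbers for stronger inhibition. In this assay compound 1 gives only a limit, > 100000 nM. Compound 2 likewise gives only a limit in this assay, > 100000 nM. Compound 3 also gives only a limit in this assay, > 100000 nM. Compound 1 differs from compound 2 by hydroxymethyl in place of ethoxycarbonyl on a saturated ring carbon; the step that the two limits leave unreadable from compound 2 to compound 1 is therefore not readable, as the limit of > 100000 nM in this assay, at which 3 of the 3 values shown sit, shows. The difference between the cores of compound 3 and compound 2 is not broken down here. Compound 4 `COc1cc([C@@H]2C[C@@]2(CO)C(=O)Nc2ccccc2Cl)cc(OC)c1OC`, not yet measured, differs from compound 3 by hydroxymethyl in place of ethoxycarbonyl on a saturated ring carbon, the same change. Since the measured analogue of this step is unreadable, compound 4 is expected to stay at the limit; the estimated step that the limit leaves unreadable from compound 3 to compound 4 rests on (the limit of > 100000 nM in this assay, at which 3 of the 3 values shown sit). The estimate for compound 4 in this assay is 150000 nM, between 60000 nM and 400000 nM.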

Compound 4, half-maximal inhibitory concentration: 18400 nM
Beside the measured number, compound 4's estimate is 8.2-fold (0.91 log units) above it; the whole stated range lies above it.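

In this assay, hydroxymethyl in place of ethoxycarbonyl on a saturated ring carbon gives an at least 5.4-fold lower number from compound 3 to compound 4 (0.73 log units; beyond the scatter), so the change lowers the number on the core of compound 3. Compound 1 and compound 2 both stay at a limit, so the same change on their core cannot be read, and it is not shown that the change does nothing there. The step therefore does not show that the change carries from one core to the other, and its full size stays unknown, since compound 3 gives only a limit: the limit of > 100000 nM in this assay, at which 3 of the 4 values shown sit.

The compounds shown leave open whether an amine or a carboxylic acid in that place would also lower the number on the core of compound 3. They also leave open whether a longer chain, such as hydroxyethyl, would do the same.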